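The source may report more compounds than this note shows. Statements on the series, on what has been measured and on what is new or still open speak of the compounds shown alone.

Among the compounds with values here, compound 2, `Cc1cc(C)c(Nc2cc(Cl)cc(C(F)(F)F)c2)c(C)c1`, stands second highest of the three numbers so far in an assay on isolated protein for binding affinity to Rap guanine nucleotide exchange factor 4 (Homo sapiens), read by cAMP accumulation (on this read-out higher numbers stand for weaker inhibition and lower numbers for stronger inhibition), where compound 2 gives 500 nM. Its nearest neighbour is compound 3, `Cc1cc(C)c(Nc2ccc(Cl)c(C(F)(F)F)c2)c(C)c1`, which in this assay gives 400 nM; the two values lie within the scatter of each other. Furthest away is compound 1, `Cc1cc(C)c(Nc2cc(F)cc(Cl)c2)c(C)c1`, which in this assay gives 2900 nM. Compound 4, `Cc1cc(C)c(Nc2cc(C(F)(F)F)cc(C(F)(F)F)c2)c(C)c1`, has not yet been measured. It differs from compound 2 in one place: trifluoromethyl in place of chloro on an aromatic carbon.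

Within the data shown here, one measured step bears on this change. Within the same shared core, trifluoromethyl in place of fluoro on an aromatic carbon gave a 5.8-fold lower number from compound 1 to compound 2 (0.76 log units; beyond the scatter). The present change also brings a trifluoromethyl onto an aromatic carbon, but what leaves is chloro rather than fluoro, and compound 2 already carries a trifluoromethyl meta to the position in question. The direction of the earlier step suggests a lower number for compound 4, while the smaller difference between what leaves and what enters argues for a step smaller than that one. Compound 4 is therefore expected to show a 1.7-fold lower number from compound 2 to compound 4 (0.22 log units; within the scatter) in this assay. The estimate for compound 4 is 300 nM, with a range from 120 nM to 800 nM.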

Compound 4, half-maximal inhibitory concentration: 600 nM
Estimate against measurement, compound 4: 2.0-fold (0.30 log units) below; measured number inside the range.
By their numbers in this assay, from the lowest: compounds 3, 2 and 4 (each within the scatter of the next); then compound 1.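

In this assay, trifluoromethyl in place of chloro at this position gives a 1.2-fold higher number from compound 2 to compound 4 (0.08 log units; within the scatter) and so leaves the number within the scatter, even though the entering group has 4 heavy atoms and the leaving group has 1. The earlier step, a 5.8-fold lower number from compound 1 to compound 2 (0.76 log units; beyond the scatter) with trifluoromethyl in place of fluoro, was beyond the scatter, so bringing a trifluoromethyl onto this ring does not by itself lower the number: the gain seen with compound 2 does not recur when chloro is the group that leaves and a trifluoromethyl group is already present. On this read-out, chloro and trifluoromethyl cannot be told apart here, and nothing available explains why this step differs from the earlier one.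

The compounds shown leave open whether the two groups would remain interchangeable without the other trifluoromethyl group on the ring. They also leave open what a nitrile, a methoxy group, an amine or a carboxylic acid would give at this position, so the tolerance seen here rests on chloro and trifluoromethyl alone.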